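Methyl to Methoxy: a Step Expected to Stay Flat

This account rests on a few compounds, and the source may have more. Where it says the series, first, only, none or still open, it means among the compounds named here.

In a functional assay, read by spectrophotometry, with a stated time of 15 min, tested at 100 ug/mL (a lower number here means a weaker effect, a higher number a stronger effect of the compound at the concentration tested), the three measured compounds give these numbers:

compound 1 `Clc1ccc(-c2csc(N/N=C/c3cccs3)n2)cc1`: 97%
compound 2 `Fc1ccc(-c2csc(N/N=C/c3ccc(Cl)cc3Cl)n2)cc1`: 96%
compound 3 `Cc1ccc(-c2csc(N/N=C/c3ccc(Cl)cc3Cl)n2)cc1`: 95.1%

Compound 3 stands at the lower edge of this tight group, yet its distance to compound 2 and to compound 1 is both times within the scatter, so the three numbers cannot be told apart.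

Compound 4 `COc1ccc(-c2csc(N/N=C/c3ccc(Cl)cc3Cl)n2)cc1` differs from compound 3 in one place: methoxy in place of methyl on an aromatic carbon. Going by the values given here, the one measured step that bears on this is the exchange at the same aromatic carbon, a number 0.9 percentage points lower from compound 2 to compound 3 (within the scatter), which was flat. A second group swap at that position is therefore expected to stay flat as well, in this assay giving a step of a number 0.1 percentage points lower from compound 3 to compound 4 (within the scatter), with no direction beyond the scatter.

Compound 4 is estimated at 95%, expected to lie between 88% and 99%.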

Compound 4, a percentage reported as inhibition, at one concentration (the size of the read-out at that concentration, not a potency): 93.3%
Compound 4: the middle estimate sits 1.7 percentage points above what was measured, within the range that was stated.
By their numbers in this assay, from the lowest: compounds 4, 3, 2 and 1 (each within the scatter of the next).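

In this assay, going from 4-methylphenyl to 4-methoxyphenyl gives a number 1.8 percentage points lower from compound 3 to compound 4 (within the scatter) and so adds a second flat step at this aromatic carbon, para to a large group. Set against fluoro, the same group gives a number 2.7 percentage points lower from compound 2 to compound 4 (within the scatter), so fluoro, methyl and methoxy cannot be told apart here, even though methoxy brings an oxygen, one more heavy atom than methyl and a hydrogen-bond acceptor. No measurement at hand offers an explanation for this flatness.

From the compounds shown here alone, whether an amine, a carboxylic acid or a chain longer than methoxy at this carbon would also stay within the scatter remains open. Also open, going by these compounds, is whether the methoxy swap would stay as flat with a different group at the far end of the shared core.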